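Pyridin-3-yl in place of 4-fluorophenyl: working notes

This account rests on a few compounds, and the source may have more. Where it says the series, first, only, none or still open, it means among the compounds named here.

In a functional assay on NCI-H1975 cells (Homo sapiens) for cytotoxicity, read by MTT assay, with a stated time of 72 h (on this read-out higher numbers stand for weaker inhibition and lower numbers for stronger inhibition), compound 1 (`O=C(N/N=C/c1ccc(F)cc1)N1CCc2ncnc(Nc3ccc(F)c(Cl)c3)c2C1`) gives 64500 nM, compound 2 (`O=C(N/N=C/c1ccc(F)cc1Cl)N1CCc2ncnc(Nc3cccc(Br)c3)c2C1`) gives 15700 nM and compound 3 (`O=C(N/N=C/c1ccc(F)cc1)N1CCc2ncnc(Nc3cccc(Br)c3)c2C1`) gives 37600 nM. Compound 3 therefore sits within the scatter of compound 1 and gives a higher number than compound 2.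

The next compound, compound 4 (`O=C(N/N=C/c1cccnc1)N1CCc2ncnc(Nc3cccc(Br)c3)c2C1`), carries pyridin-3-yl in place of 4-fluorophenyl on a carbon with a double bond to nitrogen.

Going by the values given here, only one measured step changes the ring that leaves here. Hydrogen in place of chloro on an aromatic carbon of that ring gives a 2.4-fold higher number from compound 2 to compound 3 (0.38 log units; beyond the scatter), a modest step. The change of 3-bromophenyl for 3-chloro-4-fluorophenyl on a nitrogen on an aromatic ring, a 1.7-fold lower number from compound 1 to compound 3 (0.23 log units; within the scatter), lies elsewhere in the molecule and bears on this step only as a measure of how little the numbers can move. Among the compounds with values here, no measured compound has a ring with a hetero atom at this place, so the direction remains poorly supported.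

The expected change in this assay is small and not beyond the scatter, namely a 1.2-fold higher number from compound 3 to compound 4 (0.08 log units; within the scatter). The estimate for compound 4 is 45000 nM, with an expected range of 15000 nM to 110000 nM.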

Compound 4, half-maximal inhibitory concentration: > 200000 nM
Compound 4: a limit, no number; the forecaster's own chance of this, stated with the estimate: 15%; middle value at least 4.4-fold (0.64 log units) away from the limit.
By their numbers in this assay, from the lowest: compound 2; then compounds 3 and 1 (each within the scatter of the next). At a limit, above all of these: compound 4.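

Compound 4 stands at a limit and not at a number in this assay: the limit of > 200000 nM in this assay, at which 1 of the 4 values shown sits.

Against the earlier compounds, where changes on this ring and on the aromatic nitrogen moved the read-out only slightly or modestly, this position now shows a far wider range: pyridin-3-yl in place of 4-fluorophenyl gives an at least 5.3-fold higher number from compound 3 to compound 4 (0.72 log units; beyond the scatter), and pyridin-3-yl in place of 2-chloro-4-fluorophenyl gives an at least 12-fold higher number from compound 2 to compound 4 (1.10 log units; beyond the scatter). Among the compounds shown, the one ring with a hetero atom at this place thus gives the highest reading in the series, and both steps are beyond the scatter, so the ring on the carbon with a double bond to nitrogen cannot be treated as an interchangeable part of the molecule.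

As far as these compounds go, the true size of both steps stays open, and this single change removes the fluoro group and brings in the ring nitrogen together, so the two cannot be told apart here. Plain phenyl would separate them, while pyridin-2-yl, or a phenyl ring bearing an amine or a carboxylic acid, would show whether the loss extends beyond pyridin-3-yl.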